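Dropping Both Chlorines From the Benzylamine Arm

The source may hold more compounds than are shown below. What is called first, only, known or untested is meant among the compounds shown, and "the series" means these compounds.

Compound 2 `O=S(=O)(NCCCNCc1ccc(Cl)c(Cl)c1)c1cc(C(F)(F)F)cc(C(F)(F)F)c1`: 4700 nM
Compound 1 `O=S(=O)(NCCNCc1ccc(-c2ccccc2)cc1)c1cc(C(F)(F)F)cc(C(F)(F)F)c1`: 2700 nM

In a functional assay on HT-29 cells (Homo sapiens) for inhibition, read by MTT assay, with a stated time of 72 h (a higher number here means a weaker inhibitor of growth, a lower number a stronger inhibitor of growth), compound 2 gives 4700 nM, and compound 1 gives 2700 nM. These two numbers lie within the usual scatter of each other, so neither compound can be set above the other on this evidence. Compound 3 `O=S(=O)(NCCCNCc1ccccc1)c1cc(C(F)(F)F)cc(C(F)(F)F)c1` differs from compound 2 by phenyl in place of 3,4-dichlorophenyl on a saturated chain carbon bound to an amine nitrogen. Among the compounds with values here, no measured pair of compounds covers this change. The expectation is a modest step toward a higher number in this assay, a 1.7-fold higher number from compound 2 to compound 3 (0.23 log units; within the scatter), though a result within the scatter would not surprise. Compound 3 is therefore estimated at 8000 nM, with a range from 3000 nM to 25000 nM.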

Compound 3, concentration for 50% growth inhibition: 15000 nM
Compound 3: the middle estimate sits 1.9-fold (0.27 log units) below what was measured; low and high end bracket the measured number.
By their numbers in this assay, from the lowest: compounds 1 and 2 (each within the scatter of the next); then compound 3.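

In this assay, within the data shown here, phenyl in place of 3,4-dichlorophenyl gives a 3.2-fold higher number from compound 2 to compound 3 (0.50 log units; beyond the scatter) and so provides the first step that lies beyond the scatter. The two chlorines therefore count at this place on a saturated chain carbon bound to an amine nitrogen, with compound 2 the stronger inhibitor of growth of this pair. Nothing measured here explains the size of this step.

As far as these compounds go, whether a single chlorine, a bromine or a methyl group would keep the level of compound 2 remains open. So does the effect of a longer chain in this series.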